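The compounds below may be only part of what the source reports. "The series", "measured", "known", "first", "only" and "open" are said of these compounds alone.

Compound 1 `CC1(C)C/C(=N\OC(=O)c2cccc(NC(=O)c3cccc(F)c3)c2)c2c(noc2-c2cccc(F)c2)C1`: > 25000 nM
Compound 2 `COc1cccc(C(=O)Nc2cccc(C(=O)O/N=C3\CCCc4onc(-c5ccc(OC)c(OC)c5)c43)c2)c1`: > 25000 nM
Compound 3 `Nc1cccc(C(=O)Nc2cccc(C(=O)O/N=C3\CCCc4onc(-c5ccc(F)cc5)c43)c2)c1`: > 25000 nM

In a functional assay on MCF7 cells (Homo sapiens) for antiproliferative activity, read by MTT assay, with a stated time of 72 h (a lower number here means a stronger inhibitor, a higher number a weaker inhibitor), compound 1 gives > 25000 nM, which is a limit of the assay and not a measured number. In this assay compound 2 gives > 25000 nM, again only a limit. Compound 3 gives > 25000 nM, also a limit. This is the limit of > 25000 nM in this assay, at which 3 of the 3 values shown sit, so compound 1 cannot be placed above or below the other two; the three simply share the same limit.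

Compound 4 `COc1cc(-c2onc3c2/C(=N/OC(=O)c2cccc(NC(=O)c4cccc(F)c4)c2)CC(C)(C)C3)ccc1O` differs from compound 1 by 4-hydroxy-3-methoxyphenyl in place of 3-fluorophenyl on an aromatic carbon. Within the data shown here, no measured pair shows a change of this kind, so the reach of the step is unknown. With every measured compound at the limit, compound 4 is expected to stay there, a step that the limit leaves unreadable from compound 1 to compound 4 meaning nothing beyond the scatter. The estimate for compound 4 is 30000 nM, with a range from 12000 nM to 100000 nM.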

Compound 4, half-maximal inhibitory concentration: 6200 nM
Compound 4: the middle estimate sits 4.8-fold (0.68 log units) above what was measured; the whole stated range lies above it.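

This position on the five-membered aromatic ring, next to the ring oxygen, is the first place shown where a change moves a compound off the limit in this assay: 4-hydroxy-3-methoxyphenyl in place of 3-fluorophenyl gives an at least 4.0-fold lower number from compound 1 to compound 4 (0.60 log units; beyond the scatter). Compound 1 has only a limit, so this step is a minimum and its full size stays unknown: the limit of > 25000 nM in this assay, at which 3 of the 4 values shown sit.

As far as these compounds go, the hydroxy and methoxy groups enter together, so which of them matters, or whether both do, stays open. From the compounds shown here alone, how a carboxylic acid on this phenyl ring would read also stays open.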